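The source may report more compounds than this note shows. Statements on the series, on what has been measured and on what is new or still open speak of the compounds shown alone.

Compound 1 `COc1ccccc1/C=C/c1nc(Nc2ccccc2Cl)c2ccccc2n1` carries a 2-chlorophenyl group on the amino nitrogen of its core. In an ADME assay on NHDF cells (Homo sapiens) for antiproliferative activity, with a stated time of 72 h (a higher number here means a weaker inhibitor, a lower number a stronger inhibitor), compound 1 gives > 25000 nM, which is a limit and not a number. Compound 2 `COc1ccccc1/C=C/c1nc2ccccc2c(=O)[nH]1`, which has no such amino group, gives > 25000 nM in this assay, and this too is a limit. Going by the values given here, the data therefore contain (the limit of > 25000 nM in this assay, at which 2 of the 2 values shown sit), and no measured step shows how far a change in structure can move the read-out.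

Compound 3 `COc1ccccc1/C=C/c1nc(Nc2cccc(O)c2)c2ccccc2n1` keeps the core of compound 1 but has 3-hydroxyphenyl in place of 2-chlorophenyl on a nitrogen on an aromatic ring, (3-hydroxyphenyl in place of 2-chlorophenyl on a nitrogen on an aromatic ring). The exchange adds a hydrogen-bond donor and a hydrogen-bond acceptor, and the heavy-atom count stays the same.

With no measured number to start from, only a small move toward stronger inhibition is expected in this assay, and the result may again be only a limit. The estimated change is an at least 1.3-fold lower number from compound 1 to compound 3 (0.14 log units; that floor lies within the scatter), and its size is uncertain. For compound 3 the expected value is 18000 nM, with an estimated range from 6000 nM to 25000 nM.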

Compound 3, half-maximal inhibitory concentration: 17500 nM
For compound 3 the middle estimate is 1.0-fold (0.01 log units) above the measured one, and the stated range covers the measured number.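

In this assay, going by these compounds alone, compound 3 gives 17500 nM, the first value in this set that is a number and not a limit, so a compound on the shared core can be read in this assay when 3-hydroxyphenyl stands on the nitrogen on an aromatic ring. The exchange of 2-chlorophenyl for 3-hydroxyphenyl at this place gives an at least 1.4-fold lower number from compound 1 to compound 3 (0.15 log units; that floor lies within the scatter); this step starts from a limit and so fixes only a floor, which does not by itself show a real gain in strength, while the true step may be larger. Compound 3 is thus the only compound with a number, and the other two values remain limits: the limit of > 25000 nM in this assay, at which 2 of the 3 values shown sit.

The compounds shown leave open how far the read-out of compound 1 lies from that limit, and so how large the step really is. They also leave open whether the change follows from gaining the hydroxyl or from losing the chlorine, which a plain phenyl, a 3-methoxyphenyl or a 3-aminophenyl group on the same nitrogen could help to separate.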